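Aryl swap on the amide chain of compound 3

The source may report more compounds than this note shows. Statements on the series, on what has been measured and on what is new or still open speak of the compounds shown alone.

Measured so far:
compound 1 `Cc1cccc(CNc2ccc3ncnc(Nc4cccc(Cl)c4)c3c2)n1`: 1060 nM
compound 2 `CSCCCNc1ccc2ncnc(Nc3cccc(Cl)c3)c2c1`: 3820 nM
compound 3 `O=C(/C=C/c1cccc(Br)n1)Nc1ccc2ncnc(Nc3cccc(Cl)c3)c2c1`: 4160 nM

All three share one core and differ only in the substituent hung off the ring nitrogen. In a functional assay on A549 cells (Homo sapiens) for antiproliferative activity, read by MTT assay, with a stated time of 48 h (a lower number here means a stronger inhibitor, a higher number a weaker inhibitor), compound 3 lies within the scatter of compound 2, while its gap to compound 1 is beyond the scatter. Its number is therefore among the higher ones of this small set, without being separable from compound 2.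

Among the measured compounds shown here, the only change with a measured step, a 3.6-fold higher number from compound 1 to compound 2 (0.56 log units; beyond the scatter), concerns the group on the saturated chain carbon bound to the ring nitrogen; nothing measured touches the aryl at the far end of the propenamide.

Compound 4 `O=C(/C=C/c1ccc(Br)s1)Nc1ccc2ncnc(Nc3cccc(Cl)c3)c2c1` differs from compound 3 by 5-bromothiophen-2-yl in place of 6-bromopyridin-2-yl on a double-bonded chain carbon bound to a double-bonded chain carbon. For the measured compounds named here, no measured step bears on this kind of exchange, so the expectation rests on compound 3 alone: a step of a 1.0-fold lower number from compound 3 to compound 4 (0.02 log units; within the scatter) is expected, i.e. none beyond the scatter. Going by the values given here, for compound 4 the estimate in this assay is 4000 nM, with a range from 1500 nM to 11000 nM, the width reflecting that no comparable step has been measured.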

Compound 4, half-maximal inhibitory concentration: 1580 nM
Compound 4: the middle estimate sits 2.5-fold (0.40 log units) above what was measured; measured number inside the range.
By their numbers in this assay, from the lowest: compounds 1 and 4 (each within the scatter of the next); then compounds 2 and 3 (each within the scatter of the next).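

In this assay, among the compounds shown here, the aryl at the far end of the propenamide proves sensitive to exchange, with 5-bromothiophen-2-yl in place of 6-bromopyridin-2-yl giving a 2.6-fold lower number from compound 3 to compound 4 (0.42 log units; beyond the scatter), the only measured step at this place, on a double-bonded chain carbon bound to a double-bonded chain carbon. For the compounds shown here, the earlier step showed only that the group on a saturated chain carbon bound to a nitrogen on an aromatic ring can shift the number, so the amide-linked series now has a second point of variation with a readable effect. The bromine stays while a six-membered aromatic ring gives way to a five-membered one and ring nitrogen gives way to ring sulfur, and no measurement at hand accounts for the step.

The compounds shown cannot separate ring size from the identity of the hetero atom, as both change in this one exchange; a bromophenyl group at the same place would help to divide the two. On these data alone, the contribution of the bromine also stays open, and a chlorine or a methyl in its place on the thiophene would test it.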